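Moving an acetyl analogue onto a second core

The source may hold more compounds than are shown below. What is called first, only, known or untested is meant among the compounds shown, and "the series" means these compounds.

Compound 1 `C=C(C)[C@@H]1CC=C(Cn2cc(COc3ccc(C4NC(=O)NC(C)=C4C(=O)OCC)cc3)nn2)CC1` and compound 3 `C=C(C)[C@@H]1CC=C(Cn2cc(COc3ccc(C4NC(=O)NC(C)=C4C(C)=O)cc3)nn2)CC1` share one core and differ only in the way written as methyl in place of ethoxy on a carbonyl carbon. In a functional assay on PC-3 cells (Homo sapiens) for inhibition, read by sulforhodamine B assay, with a stated time of 48 h (a lower number here means a stronger inhibitor of growth, a higher number a weaker inhibitor of growth), compound 1 gives 92200 nM, and compound 3 gives 49300 nM. The step of a 1.9-fold lower number from compound 1 to compound 3 (0.27 log units; within the scatter) is therefore small, and the two values cannot be ordered against each other.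

Compound 2 `C=C(C)[C@@H]1CC=C(Cn2cc(COc3ccccc3C3NC(=O)NC(C)=C3C(=O)OCC)nn2)CC1` has the same atoms as compound 1 joined differently; how the two cores differ is not broken down here. In this assay compound 2 gives only a limit, > 100000 nM, and no number. That one of the three values sits at this limit is recorded as the limit of > 100000 nM in this assay, at which 1 of the 3 values shown sits.

Compound 4 `C=C(C)[C@@H]1CC=C(Cn2cc(COc3ccccc3C3NC(=O)NC(C)=C3C(C)=O)nn2)CC1` has not been measured. It stands to compound 2 as compound 3 stands to compound 1: the change methyl in place of ethoxy on a carbonyl carbon is the same change, made on the core of compound 2 instead of the core of compound 1.

Since the measured version of this change gave only the small step of a 1.9-fold lower number from compound 1 to compound 3 (0.27 log units; within the scatter), and since compound 2 itself returned a limit, compound 4 is expected to fall at or near that same limit. The step of a number no higher from compound 2 to compound 4 (the limit leaves the size open) is expected to be modest. Compound 4 is estimated at 100000 nM, with a range from 45000 nM to 220000 nM, and it is quite likely that the measurement again reports only a limit.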

Compound 4, concentration for total growth inhibition: 62000 nM
Estimate against measurement, compound 4: 1.6-fold (0.21 log units) above; measured number inside the range.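

On the second core, in this assay, putting methyl in place of ethoxy on the carbonyl carbon gives an at least 1.6-fold lower number from compound 2 to compound 4 (0.20 log units; that floor lies within the scatter), and only a floor can be stated for this step, not its full size. Set beside the step on the first core, the result reads: the same change on two cores in this assay, a 1.9-fold lower number (0.27 log units; within the scatter) from compound 1 to compound 3 and an at least 1.6-fold lower number (0.20 log units; that floor lies within the scatter) from compound 2 to compound 4; the limit leaves it open whether they differ

This shows that the change from ethoxycarbonyl to acetyl, carried onto a second core, does not give a higher number there, and that compound 4 returns a measured value of 62000 nM and not a limit. It does not show that the step has the same size on both cores, nor that it reaches beyond the scatter on either of them.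

The compounds shown leave open how the two cores would respond to other groups on that carbonyl carbon, since only ethoxy and methyl stand there, and a carboxylic acid, a primary amide or a longer chain such as a propanoyl group would each be a further test of whether a change at this place carries from one core to the other. They also leave open whether the small steps seen with these four compounds in this assay would hold in any other cell line.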